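The compounds below may be only part of what the source reports. "The series", "measured", "known", "first", "only" and "open" are said of these compounds alone.

Compound 1 `O=C(Nc1cccc(Cl)c1)c1c(O)c2cccnc2n(-c2ccccc2)c1=O` and compound 2 `O=C(Nc1cccc([N+](=O)[O-])c1)c1c(O)c2cccnc2n(-c2ccccc2)c1=O` share one core and differ only in the group carried on the amide nitrogen. In a functional assay on the whole organism for inhibition, with Rattus norvegicus as the target, read by paw edema, at a dose of 100 mg/kg by the oral route (a higher number here means more inhibition at the dose given (going by the name of the read-out), a lower number less inhibition), compound 1 gives 7.6%, and in this assay compound 2 gives 5.7%. The two numbers sit within the scatter of each other, so the step of a number 1.9 percentage points lower from compound 1 to compound 2 (within the scatter) shows no real change from that swap. Compound 3 `COc1ccc(NC(=O)c2c(O)c3cccnc3n(-c3ccccc3)c2=O)cn1` is not yet measured. The change from compound 2 to it is 6-methoxypyridin-3-yl in place of 3-nitrophenyl on an amide-type nitrogen. Within the data shown here, no measured step covers this exact exchange; the only step known, the one from compound 1 to compound 2, also sits on the same amide nitrogen and was within the scatter, and both measured compounds show only small inhibition. Compound 3 is therefore expected to stay in the same low range, with a step of a number 1.3 percentage points higher from compound 2 to compound 3 (within the scatter) that is not expected to exceed the scatter. The estimate for compound 3 is 7%, between 0% and 20%.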

Compound 3, a percentage reported as inhibition, in the whole organism at one dose (the size of the read-out at that dose, not a potency): 13.1%
For compound 3 the middle estimate is 6.1 percentage points below the measured one; low and high end bracket the measured number.
By their numbers in this assay, from the lowest: compounds 2, 1 and 3 (each within the scatter of the next).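

Replacing 3-nitrophenyl with 6-methoxypyridin-3-yl on the amide-type nitrogen gives a number 7.4 percentage points higher from compound 2 to compound 3 (within the scatter) in this assay and replacing 3-chlorophenyl with it gives a number 5.5 percentage points higher from compound 1 to compound 3 (within the scatter) in the same test. The earlier pair had only six-membered aromatic rings of carbon at this position, whereas compound 3 carries a ring with one hetero atom and still cannot be told apart from either of them. Nothing at hand explains these numbers.

As far as these compounds go, all three compounds carry a six-membered aromatic ring on this nitrogen, so a plain alkyl chain or a ring bearing a carboxylic acid or an amine remains untested here. From the compounds shown here alone, whether any such group could lift the inhibition beyond the scatter stays open.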